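From fluoro to methyl on a shared core

The compounds below may be only part of what the source reports. "The series", "measured", "known", "first", "only" and "open" are said of these compounds alone.

Compound 1 `O=C(CCCCCCN1C(=O)/C(=N\O)c2cc(Br)ccc21)NO`: 2210 nM
Compound 2 `CO/N=C1/C(=O)N(CCCCCCC(=O)NO)c2ccc(F)cc21`: 1150 nM

Both compounds were tested in a functional assay on PC-3 cells (Homo sapiens) for antiproliferative activity, read by sulforhodamine B assay, with a stated time of 48 h; a higher number here means a weaker inhibitor, a lower number a stronger inhibitor. Compound 2 gives 1150 nM, a number within the scatter of compound 1 at 2210 nM, so the data do not separate the two.

Compound 3 `CO/N=C1/C(=O)N(CCCCCCC(=O)NO)c2ccc(C)cc21` has not yet been measured. It differs from compound 2 in one place: methyl in place of fluoro on an aromatic carbon. Among the compounds with values here, no measured pair isolates a single change, so the data offer no direct guide to this swap. The expectation in this assay is therefore for no step beyond the scatter, in either direction. The estimate for compound 3 is 1300 nM, with an expected range from 550 nM to 3000 nM. This expected value amounts to an estimated 1.1-fold higher number from compound 2 to compound 3 (0.05 log units; within the scatter).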

Compound 3, half-maximal inhibitory concentration: 350 nM
The estimate for compound 3 lay 3.7-fold (0.57 log units) above the measured number, outside the stated range (below it).
By their numbers in this assay, from the lowest: compound 3; then compounds 2 and 1 (each within the scatter of the next).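

In this assay, within the data shown here, methyl in place of fluoro on this aromatic carbon gives the first comparison in which only one place changes, and it brings a 3.3-fold lower number from compound 2 to compound 3 (0.52 log units; beyond the scatter) on the shared core. Each group counts a single heavy atom and neither has a hydrogen-bond donor or acceptor, so this position responds to a swap that leaves those counts unchanged. No measurement shown here bears on why the methyl compound gives the lower number.

As far as these compounds go, this single step cannot show whether the trend extends beyond methyl and fluoro, so the reading of an ethyl group, a methoxy group or an amine on this aromatic carbon remains open. From the compounds shown here alone, it also remains open whether the same step would appear with a shorter chain ending in the hydroxamic acid.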